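Iodo replaces acetyl on the oxazole of compound 2

The source may report more compounds than this note shows. Statements on the series, on what has been measured and on what is new or still open speak of the compounds shown alone.

Within the data shown here, compound 2, `CC(=O)c1cnc(C(=O)CCCCCCc2ccccc2)o1`, sits level with compound 1, `CN(C)C(=O)c1cnc(C(=O)CCCCCCc2ccccc2)o1`, on the numbers so far: in an assay (Rattus norvegicus) for inhibition of Fatty-acid amide hydrolase 1 (Homo sapiens) (on this read-out lower numbers stand for stronger inhibition and higher numbers for weaker inhibition), compound 1 gives 2 nM and compound 2 gives 2 nM. Among the measured compounds shown here, the one step measured, no change at the digits printed from compound 1 to compound 2 (within the scatter), exchanges methyl for dimethylamino on a carbonyl carbon and leaves the carbonyl in place, so it shows that this carbonyl tolerates a change of its partner without loss.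

Compound 3, `O=C(CCCCCCc1ccccc1)c1ncc(I)o1`, takes a different route: iodo in place of acetyl on an aromatic carbon. The carbonyl itself now departs and a single iodine takes its place on the five-membered ring. For the measured compounds named here, no measured step removes this carbonyl, so the step from compound 1 to compound 2 bears on it only loosely, in that it concerns the same position of the shared core. With nothing to anchor the loss of the acetyl, a weakening beyond the scatter is expected for compound 3, though a modest one, since the ketone chain and the rest of the core are untouched. Compound 3 is therefore estimated at 20 nM in this assay, within 5 nM to 80 nM, an expected step of a 10-fold higher number from compound 2 to compound 3 (1.00 log units; beyond the scatter).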

Compound 3, inhibition constant: 3 nM
Estimate against measurement, compound 3: 6.7-fold (0.82 log units) above; measured number below the stated range.
By their numbers in this assay, from the lowest: compounds 1, 2 and 3 (each within the scatter of the next).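

In this assay the change of acetyl to iodo gives a 1.5-fold higher number from compound 2 to compound 3 (0.18 log units; within the scatter) and the change of dimethylcarbamoyl to iodo gives a 1.5-fold higher number from compound 1 to compound 3 (0.18 log units; within the scatter) and so the three groups cannot be told apart on this read-out. The earlier step had changed only the partner of the carbonyl, whereas here the carbonyl itself leaves this aromatic carbon, next to the ring oxygen, along with the hydrogen-bond acceptor it carries, and a single iodine atom takes the place of the three heavy atoms of acetyl without a shift beyond the scatter. So a carbonyl at this position is shown to be dispensable for these numbers in the setting of the shared core, yet nothing available accounts for why such different groups give matching values.

Whether this tolerance extends to an amine, a carboxylic acid or a plain hydrogen on the same ring carbon stays open, since the three groups shown do not settle how far it reaches. Also open, as far as these compounds go, is how the position behaves with a shorter or longer chain on the ketone, as all three compounds carry the same chain.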